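This account rests on a few compounds, and the source may have more. Where it says the series, first, only, none or still open, it means among the compounds named here.

In a functional assay (aorta) for antagonist activity, with Oryctolagus cuniculus as the target (on this read-out lower numbers stand for stronger inhibition and higher numbers for weaker inhibition), so far:
- compound 1 `CCCCc1nc(Cl)c(CO)n1Cc1ccc(-c2ccccc2-c2nn[nH]n2)s1` gives 328 nM
- compound 2 `CCCCc1nc(Cl)c(CO)n1Cc1ccc(-c2ccccc2C(=O)O)s1` gives 4160 nM
- compound 3 `CCCCc1nc(Cl)c(C=O)n1Cc1ccc(-c2ccccc2-c2nn[nH]n2)s1` gives 330 nM

Compound 3 at 330 nM sits level with compound 1 at 328 nM, and compound 2 at 4160 nM shows much weaker inhibition than both on these numbers. Compound 4 `CCCCc1nc(Cl)c(C=O)n1Cc1ccc(-c2ccccc2C(=O)O)s1` is compound 3 with carboxy in place of 2H-tetrazol-5-yl on an aromatic carbon, on a six-membered aromatic ring of carbon only, ortho to a large group.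

The same exchange has been measured once, in the hydroxymethyl pair (a 13-fold higher number from compound 1 to compound 2 (1.10 log units; beyond the scatter)), a large step beyond the scatter towards weaker inhibition. The other measured step, formyl in place of hydroxymethyl (a 1.0-fold higher number from compound 1 to compound 3 (0.00 log units; within the scatter)), stays within the scatter, so the formyl and hydroxymethyl compounds offer no reason to expect a different size of exchange step. As far as these compounds go, whether the step carries over unchanged is untested, and it rests on a single pair.

A similarly large rise is therefore expected (a 13-fold higher number from compound 3 to compound 4 (1.10 log units; beyond the scatter)), beyond the scatter. The estimate for compound 4 is 4200 nM with an expected range from 1600 nM to 11000 nM in this assay here.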

Compound 4, half-maximal inhibitory concentration: 2000 nM
For compound 4 the middle estimate is 2.1-fold (0.32 log units) above the measured one; measured number inside the range.
By their numbers in this assay, from the lowest: compounds 1 and 3 (each within the scatter of the next); then compound 4; then compound 2.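

In this assay, carboxy in place of 2H-tetrazol-5-yl on an aromatic carbon again moves towards weaker inhibition, with a 6.1-fold higher number from compound 3 to compound 4 (0.78 log units; beyond the scatter), so this loss no longer rests on a single pair and holds with both hydroxymethyl and formyl present, at sizes that cannot be told apart: the same change on two cores in this assay, a 13-fold higher number (1.10 log units; beyond the scatter) from compound 1 to compound 2 and a 6.1-fold higher number (0.78 log units; beyond the scatter) from compound 3 to compound 4, 2.1-fold (0.32 log units) apart, within the scatter of two such steps. Formyl in place of hydroxymethyl, which made no difference between the 2H-tetrazol-5-yl compounds, gives a 2.1-fold lower number from compound 2 to compound 4 (0.32 log units; beyond the scatter) among the carboxy compounds, a modest step towards stronger inhibition. This does not show that the effect of formyl depends on the group on the aromatic ring, because the two formyl steps lie within the scatter of each other: the same change on two cores in this assay, a 1.0-fold higher number (0.00 log units; within the scatter) from compound 1 to compound 3 and a 2.1-fold lower number (0.32 log units; beyond the scatter) from compound 2 to compound 4, 2.1-fold (0.32 log units) apart, within the scatter of two such steps.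

Open, as far as these compounds go, is whether a sulfonamide or a primary amide on this aromatic carbon, ortho to a large group, would stay level with the 2H-tetrazol-5-yl compounds or fall towards the carboxy compounds. Also open, from the compounds shown here alone, is how a carboxylic acid or a methyl ester would read in the place held by hydroxymethyl and formyl, where these two groups alone give little separation.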